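The source may report more compounds than this note shows. Statements on the series, on what has been measured and on what is new or still open speak of the compounds shown alone.

Measured compounds in an assay on isolated protein for inhibition of alkaline phosphatase, tissue-nonspecific isozyme (Bos taurus), read by spectrophotometry, with stated times of 7 min and 15 min; on this read-out lower numbers stand for stronger inhibition and higher numbers for weaker inhibition:
- compound 1, `COc1ccc(Cn2c(-c3ccc(C)cc3)c(Br)c(=O)c3cc([N+](=O)[O-])ccc32)cc1`, gives 4220 nM
- compound 2, `Cc1ccc(-c2c(Br)c(=O)c3cc([N+](=O)[O-])ccc3n2C(C)c2ccccc2)cc1`, gives 1340 nM
- compound 3, `COc1ccc(Cn2c(-c3ccc(C)cc3)c(C(F)(F)F)c(=O)c3cc([N+](=O)[O-])ccc32)cc1`, gives 4530 nM

Among these three, compound 2 has the lowest number in this assay, and both of its gaps to the others are larger than the usual scatter. Among the compounds with values here, the only change that moved the number in this set is the one on the aromatic nitrogen: a 3.1-fold lower number from compound 1 to compound 2 (0.50 log units; beyond the scatter). The other change, on the aromatic carbon, did not: a 1.1-fold higher number from compound 1 to compound 3 (0.03 log units; within the scatter).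

Compound 4, `Cc1ccc(-c2[nH]c3ccc([N+](=O)[O-])cc3c(=O)c2Br)cc1`, takes the step further at the same position. Here (hydrogen in place of 1-phenylethyl on an aromatic nitrogen). Within the data shown here, no measured pair shows what happens when the group on the aromatic nitrogen is removed altogether; the step from compound 1 to compound 2 only shows that swapping one such group for another can shift the number beyond the scatter. Taking away the whole 1-phenylethyl is a larger change than that swap, so the number for compound 4 is expected to move, most likely upward, toward weaker inhibition, but the size is uncertain. The expected step is a 3.7-fold higher number from compound 2 to compound 4 (0.57 log units; beyond the scatter). Compound 4 is therefore estimated at 5000 nM, within a range from 1500 nM to 20000 nM.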

Compound 4, half-maximal inhibitory concentration: 6470 nM
Compound 4: the middle estimate sits 1.3-fold (0.11 log units) below what was measured, and the stated range covers the measured number.
By their numbers in this assay, from the lowest: compound 2; then compounds 1, 3 and 4 (each within the scatter of the next).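

Removing the 1-phenylethyl altogether gives a 4.8-fold higher number from compound 2 to compound 4 (0.68 log units; beyond the scatter) in this assay, so this group is tied to a lower number, yet compound 4, with only hydrogen on the aromatic nitrogen, still gives a measurable value. Putting hydrogen in place of 4-methoxybenzyl gives a 1.5-fold higher number from compound 1 to compound 4 (0.19 log units; within the scatter) in this assay, so among these compounds a large group on this nitrogen does not by itself lower the number: compound 1 carries 4-methoxybenzyl and goes against any such rule, and only the 1-phenylethyl of compound 2 stands apart. Nothing given here accounts for the difference between these two groups on the nitrogen.

The compounds shown leave open whether plain benzyl, without the extra methyl of 1-phenylethyl and without the methoxy of 4-methoxybenzyl, would behave like hydrogen or like 1-phenylethyl. They also leave open what a small methyl or a longer chain such as butyl would do on this nitrogen, and whether the step seen with the bromo compounds would recur with trifluoromethyl on the aromatic carbon.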